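A few compounds are considered here, and "the series" means these few. Any claim that something is new, unique, unknown or untested is made for them only; others in the source may bear on it.

Compound 1 `N#Cc1cnc(NCc2cnccc2C(F)(F)F)cc1N[C@H]1C[C@@H](O)C1` in an assay on isolated protein for inhibition of protein kinase C delta type (Homo sapiens), read by TR-FRET, with a stated time of 2 h (on this read-out lower numbers stand for stronger inhibition and higher numbers for weaker inhibition), gives only the assay's limit > 10000 nM.
Compound 2 `CO[C@H]1CC[C@H](CNc2cc(NCc3cnccc3C(F)(F)F)ncc2C#N)CC1` in this assay gives only the limit > 10000 nM.
Compound 3 `N#Cc1cnc(NCc2cnccc2C(F)(F)F)cc1NCCC1CCOCC1` in this assay gives only the limit > 10000 nM.

All three compounds share one core and differ only in the group carried on a nitrogen on an aromatic ring. Because every value sits at the limit of > 10000 nM in this assay, at which 3 of the 3 values shown sit, none of the three measured steps can be read: a step that the two limits leave unreadable from compound 1 to compound 2, a step that the two limits leave unreadable from compound 1 to compound 3 and a step that the two limits leave unreadable from compound 2 to compound 3 are each hidden by the limit on both sides. Compound 3 therefore stands nowhere in particular among the numbers shown; it is one of three compounds the assay could not tell apart.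

Compound 4 `CC1(C)[C@@H](Nc2cc(NCc3cnccc3C(F)(F)F)ncc2C#N)C[C@H]1C(N)=O` is not yet measured. It differs from compound 3 in one place: 3-carbamoyl-2,2-dimethylcyclobutyl in place of 2-(oxan-4-yl)ethyl on a nitrogen on an aromatic ring. Among the compounds with values here, no measured step bears on this change; the three measured steps are unreadable, and the three groups already tried all returned no number. The shown data thus give neither a direction nor a size for the expected step of an at least 1.2-fold lower number from compound 3 to compound 4 (0.09 log units; that floor lies within the scatter), and the expectation is simply that compound 4 stays near the limit, possibly with a readable value at the weak end. The estimate for compound 4 in this assay is 8000 nM, with a range from 1000 nM to 30000 nM.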

Compound 4, half-maximal inhibitory concentration: 4500 nM
Compound 4: middle estimate off by 1.8-fold (0.25 log units), on the high side, within the range that was stated.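

Placing 3-carbamoyl-2,2-dimethylcyclobutyl on this nitrogen gives an at least 2.2-fold lower number from compound 3 to compound 4 (0.34 log units; beyond the scatter), an at least 2.2-fold lower number from compound 2 to compound 4 (0.34 log units; beyond the scatter) and an at least 2.2-fold lower number from compound 1 to compound 4 (0.34 log units; beyond the scatter), so in this assay this position does respond to the group it carries, although compound 4 still gives only 4500 nM. The four-membered ring alone does not explain the change, as compound 1 also carries one, in its 3-hydroxycyclobutyl group, and gives no number. Each of these steps is only a minimum size, and the steps among compounds 1, 2 and 3 cannot be read, as the true values of those three compounds remain hidden: the limit of > 10000 nM in this assay, at which 3 of the 4 values shown sit.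

The group in compound 4 differs from the 3-hydroxycyclobutyl group of compound 1 in both its carbamoyl group and its two methyl groups, so the compounds shown do not tell which of these matters, or whether both are needed. A plain 3-carbamoylcyclobutyl group without the methyl groups, a 3-hydroxy-2,2-dimethylcyclobutyl group, or a carboxylic acid in place of the carbamoyl group would separate these parts, and the mirror-image form of the group in compound 4 would test whether its stereocentres matter.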